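A few compounds are considered here, and "the series" means these few. Any claim that something is new, unique, unknown or untested is made for them only; others in the source may bear on it.

Measured so far in a functional assay on DU-145 cells (Homo sapiens) for inhibition, read by trypan blue exclusion, with a stated time of 72 h; on this read-out higher numbers stand for weaker inhibition and lower numbers for stronger inhibition
compound 1 `Cn1c(=O)c(S(=O)(=O)c2ccc(F)cc2F)cc2cnc(Nc3cccc4[nH]ccc34)nc21` gives 750 nM
compound 2 `Cn1ccc2cc(Nc3ncc4cc(S(=O)(=O)c5ccc(F)cc5F)c(=O)n(C)c4n3)ccc21` gives 750 nM
compound 3 `Cc1cc2cc(Nc3ncc4cc(S(=O)(=O)c5ccc(F)cc5F)c(=O)n(C)c4n3)ccc2[nH]1` gives 750 nM

Compound 1 stands level with compounds 2 and 3 at the digits shown, so the set has no separation yet. The next compound to read is compound 4 `Cn1c(=O)c(S(=O)(=O)c2ccc(F)cc2)cc2cnc(Nc3cccc4[nH]ccc34)nc21`, and its difference from compound 1 is hydrogen in place of fluoro on an aromatic carbon (hydrogen in place of fluoro on an aromatic carbon, with 2,4-difluorophenyl becoming 4-fluorophenyl).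

Three measured steps are available. They are no change at the digits printed from compound 1 to compound 2 (within the scatter), then no change at the digits printed from compound 1 to compound 3 (within the scatter), and finally no change at the digits printed from compound 2 to compound 3 (within the scatter), and none of them goes beyond the scatter. All three alter the group on the nitrogen and leave the 2,4-difluorophenyl untouched. For the measured compounds named here, the data therefore hold no pair that differs at this fluoro, and these steps bear on the change only indirectly, as a sign of how flat the set has been so far. No step beyond the scatter is expected in this assay, and neither direction is favoured. The estimated step is no change at the digits printed from compound 1 to compound 4 (within the scatter) in this read-out. From the compounds shown here alone, for compound 4 the expected value is 750 nM, with an estimated range from 300 nM to 1900 nM, kept wide since this position is untested.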

Compound 4, half-maximal inhibitory concentration: 750 nM
Compound 4: middle estimate and measured number agree at the digits printed, and the stated range covers the measured number.
By their numbers in this assay, from the lowest: compounds 1, 2, 3 and 4 (each within the scatter of the next).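

In this assay, for the compounds shown here, the fluoro on the aromatic carbon ortho to a large group is now tested for the first time, and replacing it with hydrogen gives no change at the digits printed from compound 1 to compound 4 (within the scatter). With the 1H-indol-4-yl group held constant, 2,4-difluorophenyl and 4-fluorophenyl therefore read alike, which extends the flat picture from the group on the nitrogen to the aryl sulfonyl side of the series, and this fluoro is not needed to keep the reading of compound 1 in this cell assay. No measurement on hand bears on why the two compounds read alike.

Going by these compounds alone, the single pair leaves open whether the same holds with 1-methyl-1H-indol-5-yl or 2-methyl-1H-indol-5-yl on the nitrogen, and what happens if the remaining fluoro of the 4-fluorophenyl group is also replaced by hydrogen. Within the data shown here, it is also open whether a methoxy group, a dimethylamino group or a carboxylic acid at the position tested here would separate from the fluoro and hydrogen compounds, since hydrogen and fluoro are the only two groups compared there.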